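Swapping a benzoyl for a heptanoyl in a diacylhydrazine

A few compounds are considered here, and "the series" means these few. Any claim that something is new, unique, unknown or untested is made for them only; others in the source may bear on it.

Of the compounds shown here, three have been measured in an assay on cells for agonist activity at ecdysone receptor (Bombyx mori), read by a luciferase reporter, with a stated time of 24 h; a lower number here means that less compound is needed, a higher number that more compound is needed for the effect. Compound 1 `Cc1cc(C)cc(C(=O)N(NC(=O)c2ccccc2)C(C)(C)C)c1` gives 69.2 nM in this assay. Compound 2 `CC(C)(C)N(NC(=O)c1ccccc1Cl)C(=O)c1ccccc1Cl`, which carries a chloro substituent on each aromatic ring, gives 331 nM in this assay. Compound 3 `CCc1ccc(C(=O)NN(C(=O)c2ccccc2)C(C)(C)C)cc1` gives 4.9 nM in this assay, the lowest number of the three and beyond the scatter from both of the others, so compound 3 stands as the most potent of the set.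

Compound 4 `CCCCCCC(=O)N(NC(=O)c1ccc(CC)cc1)C(C)(C)C` has not yet been measured. It differs from compound 3 by hexyl in place of phenyl on a carbonyl carbon, so one of the two aromatic acyl groups of compound 3 is exchanged for an aliphatic one of the same heavy-atom count. Among the compounds with values here, no measured pair in this set makes that kind of exchange, so there is no directly comparable step to lean on. All three measured compounds keep both aromatic acyl groups, and the exchange in compound 4 removes one of them; a step well beyond the scatter towards a higher number is expected for a 31-fold higher number from compound 3 to compound 4 (1.49 log units; beyond the scatter). Compound 4 is therefore estimated at 150 nM in this assay, within a range of 20 nM to 2000 nM.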

Compound 4, half-maximal effective concentration: 11700 nM
For compound 4 the middle estimate is 78-fold (1.89 log units) below the measured one; measured number outside the range, above it.
By their numbers in this assay, from the lowest: compound 3; then compound 1; then compound 2; then compound 4.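

In this assay, this position tolerates the exchange of benzoyl for hexylcarbonyl very poorly, giving a 2400-fold higher number from compound 3 to compound 4 (3.38 log units; beyond the scatter), although both groups count 6 heavy atoms and neither phenyl nor hexyl brings hydrogen-bond donors or acceptors. The earlier compounds shown here all keep an aromatic ring on both acyl groups, so they could not show what happens without one; this step shows that matching the heavy-atom count with an open chain does not preserve the low number of compound 3, at least in this single pair. No measurement at hand accounts for the size of this step.

Whether a shorter chain such as butyl, a saturated ring such as cyclohexyl, or a benzyl group on this carbonyl carbon would give a number closer to that of compound 3 stays open, as the compounds shown carry only aromatic rings or the hexyl chain there. Also open, from the compounds shown here alone, is whether the same exchange on the other acyl group of compound 3 would cost as much.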